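Aroylthiophene series: chloro to ethoxy at the pendant ring

This account rests on a few compounds, and the source may have more. Where it says the series, first, only, none or still open, it means among the compounds named here.

Measured compounds:
- compound 1, `COc1cc(C(=O)c2sc(-c3ccc(C)cc3)cc2N)cc(OC)c1OC`, 16 nM
- compound 2, `COc1cc(C(=O)c2sc(-c3ccc(Cl)cc3)cc2N)cc(OC)c1OC`, 77 nM
- compound 3, `COc1cc(C(=O)c2sc(-c3cc(OC)c(OC)c(OC)c3)cc2N)cc(OC)c1OC`, 1200 nM

In a functional assay on MOLT-4 cells (Homo sapiens) for antiproliferative activity (on this read-out lower numbers stand for stronger inhibition and higher numbers for weaker inhibition), compound 2 stands second highest of the three numbers. Among the measured compounds shown here, its nearest neighbour is compound 1, which gives 16 nM, and the one measured step that reaches compound 2, a 4.8-fold higher number from compound 1 to compound 2 (0.68 log units; beyond the scatter), is the only single change at this position on record. For the measured compounds named here, compound 3, with 1200 nM, sits far above both, but no single-change step connects it to compound 2, so it only shows that heavier substitution on that ring can go with a much higher number.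

Compound 4, `CCOc1ccc(-c2cc(N)c(C(=O)c3cc(OC)c(OC)c(OC)c3)s2)cc1`, is unmeasured. Compared with compound 2 the change is ethoxy in place of chloro on an aromatic carbon.

The methyl-to-chloro step was modest and beyond the scatter, so a step of comparable size in this assay is plausible here too, in either direction; nothing measured distinguishes ethoxy at this place from methyl or chloro. The expectation for compound 4 is 30 nM, within 8 nM to 120 nM. That estimate corresponds to a 2.6-fold lower number from compound 2 to compound 4 (0.41 log units; beyond the scatter), a step that is expected to lean toward a lower number but may fall within the scatter.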

Compound 4, half-maximal inhibitory concentration: 240 nM
The estimate for compound 4 lay 8.0-fold (0.90 log units) below the measured number; measured number above the stated range.
By their numbers in this assay, from the lowest: compound 1; then compound 2; then compound 4; then compound 3.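

In this assay, the position carrying the pendant ring's single substituent responds clearly to an oxygen-linked chain: 4-chlorophenyl to 4-ethoxyphenyl gives a 3.1-fold higher number from compound 2 to compound 4 (0.49 log units; beyond the scatter). Against the methyl group the change is larger, with a 15-fold higher number from compound 1 to compound 4 (1.18 log units; beyond the scatter), so the three groups at this place now form an order, with methyl giving the lowest number, then chloro, then ethoxy. No measurement on hand accounts for this order.

The compounds shown do not separate the effect of the ether oxygen from that of the longer chain, a question that a lone methoxy or an ethyl group at this place would address. Going by these compounds, how an amine or a carboxylic acid at this place would read in this assay also remains open.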